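Ester to acid at the oxalyl end, with and without benzoyl

A few compounds are considered here, and "the series" means these few. Any claim that something is new, unique, unknown or untested is made for them only; others in the source may bear on it.

Compound 1 `CCOC(=O)C(=O)CC(=O)/C=C/c1cn(Cc2ccccc2)c2ccccc12` — > 40000 nM
Compound 2 `O=C(/C=C/c1cn(Cc2ccccc2)c2ccccc12)CC(=O)C(=O)O` — 15000 nM
Compound 3 `CCOC(=O)C(=O)CC(=O)/C=C/c1cc(C(=O)c2ccccc2)cn1Cc1ccccc1` — "not determined" (no result reported)

Three compounds were tested in a functional assay on MOLT-4 cells (Homo sapiens) for inhibition, read by MTT assay, with a stated time of 48 h; on this read-out higher numbers stand for weaker inhibition and lower numbers for stronger inhibition. Compound 1 `CCOC(=O)C(=O)CC(=O)/C=C/c1cn(Cc2ccccc2)c2ccccc12` reached only the limit of the assay, > 40000 nM, so no number is known for it. Compound 2 `O=C(/C=C/c1cn(Cc2ccccc2)c2ccccc12)CC(=O)C(=O)O` differs from it in one place, (hydrogen in place of ethyl on an oxygen next to a carbonyl group), and in this assay compound 2 gives 15000 nM. The step of an at least 2.6-fold lower number from compound 1 to compound 2 (0.42 log units; beyond the scatter) can only be stated as a lower bound, because compound 1 sits at the limit of > 40000 nM in this assay, at which 1 of the 3 values shown sits.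

Compound 3 `CCOC(=O)C(=O)CC(=O)/C=C/c1cc(C(=O)c2ccccc2)cn1Cc1ccccc1` carries a benzoyl group on the core; how its core differs from that of compound 1 is not broken down here. For compound 3 no result was reported, "not determined" (no result reported), so the benzoyl core has no measured anchor of its own.

Compound 4 `O=C(/C=C/c1cc(C(=O)c2ccccc2)cn1Cc1ccccc1)CC(=O)C(=O)O` stands to compound 3 as compound 2 stands to compound 1: the change is hydrogen in place of ethyl on an oxygen next to a carbonyl group, the same change as before, made on the same kind of oxygen. Among the compounds with values here, since compound 3 has no value, the expectation for compound 4 rests on compound 2 alone, whose value 15000 nM is the only number, and on the direction of the step of an at least 2.6-fold lower number from compound 1 to compound 2 (0.42 log units; beyond the scatter). Compound 4 is therefore expected to land near compound 2, at about 15000 nM, with a plausible range from 4000 nM to 50000 nM.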

Compound 4, half-maximal inhibitory concentration: > 40000 nM
Compound 4: only a limit was reported; the forecaster's own chance of this, stated with the estimate: 25%; middle value at least 2.6-fold (0.42 log units) from the limit.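

In this assay compound 4 gives > 40000 nM, which is a limit and not a number: the limit of > 40000 nM in this assay, at which 2 of the 4 values shown sit. Compound 3 offers no number to set against it, so no step can be read from compound 3 to compound 4. The compounds shown leave open how the benzoyl core compares with the core of compound 1, and how large the ester-to-acid change is on the benzoyl core.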